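The source may report more compounds than this note shows. Statements on the series, on what has been measured and on what is new or still open speak of the compounds shown alone.

Measured compounds in a functional assay on BGC-823 cells (Homo sapiens) for inhibition, read by MTT assay, with a stated time of 72 h; a lower number here means a stronger inhibitor, a higher number a weaker inhibitor:

- compound 1, `Cc1cc(N2CC[C@@H](C)[C@@H](N(C)c3ncnc4[nH]ccc34)C2)n2nc(SCC3CCCCC3)nc2n1`: compound 1 gives 16300 nM
- compound 2, `Cc1cc(N2CC[C@@H](C)[C@@H](N(C)c3ncnc4[nH]ccc34)C2)n2nc(SCc3ccc(C(F)(F)F)cc3)nc2n1`: compound 2 gives 23300 nM
- compound 3, `Cc1cc(N2CC[C@@H](C)[C@@H](N(C)c3ncnc4[nH]ccc34)C2)n2nc(SCC3CC3)nc2n1`: compound 3 gives 36500 nM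

All three share the same core and differ only in the group on the saturated chain carbon bound to the sulfur. Compound 3 carries the highest of the three numbers; against compound 2 the gap is a 1.6-fold higher number from compound 2 to compound 3 (0.19 log units; within the scatter), which stays within the scatter, while against compound 1 the gap is a 2.2-fold higher number from compound 1 to compound 3 (0.35 log units; beyond the scatter), a modest step beyond it. The step of a 1.4-fold higher number from compound 1 to compound 2 (0.16 log units; within the scatter) shows that the cyclohexyl and the 4-(trifluoromethyl)phenyl cannot be told apart here.

Compound 4, `Cc1cc(N2CC[C@@H](C)[C@@H](N(C)c3ncnc4[nH]ccc34)C2)n2nc(SCc3cc(Cl)ccc3Cl)nc2n1`, has not yet been measured. The change from compound 3 is 2,5-dichlorophenyl in place of cyclopropyl on a saturated chain carbon bound to a sulfur. The closest comparison is the pair compound 2 and compound 3, where an aromatic group gave way to cyclopropyl and the number rose only within the scatter. Replacing cyclopropyl with another aromatic group is therefore expected to give at most a small step, likely in the direction of a lower number, but the data do not separate one aryl from another.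

Compound 4 is expected to read 22000 nM, with a range from 9000 nM to 50000 nM. The step expected from this is a 1.7-fold lower number from compound 3 to compound 4 (0.22 log units; within the scatter).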

Compound 4, half-maximal inhibitory concentration: 18900 nM
Compound 4: the middle estimate sits 1.2-fold (0.07 log units) above what was measured; measured number inside the range.
By their numbers in this assay, from the lowest: compounds 1, 4, 2 and 3 (each within the scatter of the next, the first and the last beyond it).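

In this assay, the 2,5-dichlorophenyl of compound 4 brings a second aromatic ring, with chlorine on it, to this place on a saturated chain carbon bound to a sulfur, and it cannot be told apart from 4-(trifluoromethyl)phenyl (a 1.2-fold lower number from compound 2 to compound 4 (0.09 log units; within the scatter)) or from cyclohexyl (a 1.2-fold higher number from compound 1 to compound 4 (0.06 log units; within the scatter)). The exchange of cyclopropyl, with 3 heavy atoms, for 2,5-dichlorophenyl, with 8, also stays within the scatter (a 1.9-fold lower number from compound 3 to compound 4 (0.29 log units; within the scatter)), so compound 4 lies within the scatter of all three earlier compounds and does not widen the spread of the series, aromatic and non-aromatic rings alike giving numbers of similar size here. No measurement available bears on the reason for this flat response.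

Still open, from the compounds shown here alone, is whether a group of another kind on this carbon, such as an amine, a carboxylic acid or a longer chain, would give a step clearly beyond the scatter. Also open, going by these compounds, is whether the chlorine pattern matters at all, which a comparison of 2,5-dichlorophenyl with plain phenyl or 4-chlorophenyl would address.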